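Adding Methylsulfanyl to a Compound Already at the Limit

The source may hold more compounds than are shown below. What is called first, only, known or untested is meant among the compounds shown, and "the series" means these compounds.

Compound 1, `CCCCC[Se]c1nc(NCc2ccc(SC)cc2)c2ccccc2n1`: in a functional assay on HTB-54 cells (Homo sapiens) for cytotoxicity, read by MTT assay, with a stated time of 72 h (a lower number here means a stronger inhibitor of growth, a higher number a weaker inhibitor of growth), compound 1 gives 81300 nM.
Compound 2, `CSc1ccc(CNc2nc([SeH])nc3ccccc23)cc1`: in this assay compound 2 gives > 100000 nM, which is a limit of the assay.
Compound 3, `C[Se]c1nc(NCc2ccccc2)c2ccccc2n1`: in this assay compound 3 gives > 100000 nM, which is a limit of the assay.

Compound 3 thus stands at the limit of > 100000 nM in this assay, at which 2 of the 3 values shown sit, and no number of its own is known for it. The change that leads to compound 4, `CSc1ccc(CNc2nc([Se]C)nc3ccccc23)cc1`, is methylsulfanyl in place of hydrogen on an aromatic carbon. Among the compounds with values here, the only measured step, an at least 1.2-fold higher number from compound 1 to compound 2 (0.08 log units; that floor lies within the scatter), concerns the group on the selenium and not the aromatic ring, so none of the measured steps speaks to this change. Compound 1 carries the methylsulfanyl group and gives a number close to the limit. Compound 2 also carries the methylsulfanyl group and sits at the limit. For compound 4 the expected step is a number no higher from compound 3 to compound 4 (the limit leaves the size open), which means that no movement beyond the scatter is anticipated. Compound 4 is therefore expected to give about 100000 nM in this assay, within a range from 50000 nM to 300000 nM, most probably reported again as a limit.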

Compound 4, concentration for total growth inhibition: 72400 nM
Compound 4: the middle estimate sits 1.4-fold (0.14 log units) above what was measured, within the range that was stated.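

Within the data shown here, with methylsulfanyl in place of hydrogen on an aromatic carbon, para to a large group, this assay now gives a first reading of this change: an at least 1.3-fold lower number from compound 3 to compound 4 (0.14 log units; that floor lies within the scatter), which is only a floor and does not establish a shift beyond the scatter. Among these compounds, the methyl on the selenium can be read in the same limited way, with an at least 1.3-fold lower number from compound 2 to compound 4 (0.14 log units; that floor lies within the scatter), while the one step between two numbers, a 1.1-fold lower number from compound 1 to compound 4 (0.05 log units; within the scatter), shows that with methylsulfanyl in place, the methyl and pentyl chains on the selenium cannot be told apart in this assay. Compound 1 and compound 4, both carrying methylsulfanyl, are thus the two compounds with numbers of their own, and the other two stay at the limit: the limit of > 100000 nM in this assay, at which 2 of the 4 values shown sit.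

On these data alone, the true size of the step to compound 4 stays open, as does whether an amine, a carboxylic acid or a methoxy group at the same aromatic carbon would give a number of its own. Also open, as far as these compounds go, is whether a chain on the selenium longer than pentyl, or an amine at the end of such a chain, would move the number beyond the scatter.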